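The compounds below may be only part of what the source reports. "The series", "measured", "known", "first", "only" and "open" are said of these compounds alone.

Working notes on the series. In a functional assay on cells (leukaemia cell line, Homo sapiens) for inhibition, read by sulforhodamine B assay, with a stated time of 48 h (a lower number here means a stronger inhibitor of growth, a higher number a weaker inhibitor of growth), compound 1 (`O=S(=O)(Nc1ccc(Br)c(Cl)c1)c1ccc(-c2cnc(C3CC3)o2)cc1`) gives 70300 nM and compound 2 (`O=S(=O)(Nc1cc(F)cc(Cl)c1)c1ccc(-c2cnc(C3CC3)o2)cc1`) gives 77500 nM, so the two stand level within the scatter. The next compound to read is compound 3 (`Cc1cc(F)cc(NS(=O)(=O)c2ccc(-c3cnc(C4CC4)o3)cc2)c1`), which has methyl in place of chloro on an aromatic carbon, meta to a fluoro group, turning 3-chloro-5-fluorophenyl into 3-fluoro-5-methylphenyl: methyl in place of chloro on an aromatic carbon. Going by the values given here, only one measured step bears on this change, and only indirectly. It is a 1.1-fold higher number from compound 1 to compound 2 (0.04 log units; within the scatter), where 3-chloro-5-fluorophenyl takes the place of 4-bromo-3-chlorophenyl on a sulfonamide nitrogen. Among the compounds with values here, no measured pair exchanges chloro for methyl, so the direct effect of this swap is unknown. Within the data shown here, the one step available, on the same aryl group, gives no reason to expect a move in either direction in this assay. The estimated change is a 1.0-fold higher number from compound 2 to compound 3 (0.01 log units; within the scatter), which means no shift beyond the scatter is expected. In this assay the expected value for compound 3 is 80000 nM, with an estimated range of 50000 nM to 120000 nM.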

Compound 3, concentration for total growth inhibition: 7250 nM
For compound 3 the middle estimate is 11-fold (1.04 log units) above the measured one; the whole stated range lies above it.
By their numbers in this assay, from the lowest: compound 3; then compounds 1 and 2 (each within the scatter of the next).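

In this assay the aryl group on the sulfonamide nitrogen now proves able to shift the number, which the earlier step within the scatter did not show: with methyl in place of chloro on an aromatic carbon, meta to a fluoro group, the result is an 11-fold lower number from compound 2 to compound 3 (1.03 log units; beyond the scatter). The same holds against the other chlorinated aryl group, with 3-fluoro-5-methylphenyl in place of 4-bromo-3-chlorophenyl giving a 9.7-fold lower number from compound 1 to compound 3 (0.99 log units; beyond the scatter), so among these three compounds the one lacking chloro stands apart, and neither of the other two goes against this. No measurement offered here bears on the reason for this shift.

The compounds shown leave open whether the gain belongs to methyl itself or to the departure of chloro, a distinction that hydrogen, ethyl or methoxy on the same aromatic carbon would help to draw. They also leave open whether the fluoro group contributes to the lower number of compound 3, and whether methyl would have the same effect in the 4-bromo-3-chlorophenyl setting.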